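This account rests on a few compounds, and the source may have more. Where it says the series, first, only, none or still open, it means among the compounds named here.

Three compounds from one series were tested in a functional assay on HeLa cells (Homo sapiens) for cytotoxicity, read by MTT assay; on this read-out higher numbers stand for weaker inhibition and lower numbers for stronger inhibition. Compound 1 `COC(=O)C[C@@H]1C[C@@H](O)[C@H](C)[C@H](c2ccccc2)N1` gives 6500 nM. Compound 2 `COC(=O)C[C@H]1C[C@H](O)[C@@H](C)[C@@H](c2ccc(OC)cc2)N1`, which carries a different core, gives 5300 nM; the difference between the two cores is not broken down here. Compound 3 `C[C@H]1[C@H](O)C[C@@H](CCO)N[C@H]1c1ccccc1` gives 31500 nM. From compound 1 to compound 3 the change is hydroxymethyl in place of methoxycarbonyl on a saturated chain carbon bound to a saturated ring carbon, and it produced a 4.8-fold higher number from compound 1 to compound 3 (0.69 log units; beyond the scatter).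

Compound 4 `COc1ccc([C@H]2N[C@@H](CCO)C[C@H](O)[C@H]2C)cc1` has not yet been measured in this assay. It differs from compound 2 by hydroxymethyl in place of methoxycarbonyl on a saturated chain carbon bound to a saturated ring carbon, the same change made from compound 1 to compound 3, at the same place. Compound 4 is therefore expected to show a 4.7-fold higher number from compound 2 to compound 4 (0.67 log units; beyond the scatter), a step of about the size already seen, because compound 2 sits at 5300 nM and the earlier step was a 4.8-fold higher number from compound 1 to compound 3 (0.69 log units; beyond the scatter). On that basis compound 4 is estimated at 25000 nM, expected to lie between 12000 nM and 55000 nM.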

Compound 4, half-maximal inhibitory concentration: 16500 nM
Compound 4: middle estimate off by 1.5-fold (0.18 log units), on the high side; low and high end bracket the measured number.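

In this assay, the step of a 3.1-fold higher number from compound 2 to compound 4 (0.49 log units; beyond the scatter) shows that hydroxymethyl in place of methoxycarbonyl again gives a higher number on a second core. The change therefore carries over from the core of compound 1 to the core of compound 2 in direction, and the two steps do not differ in size beyond the scatter: the same change on two cores in this assay, a 4.8-fold higher number (0.69 log units; beyond the scatter) from compound 1 to compound 3 and a 3.1-fold higher number (0.49 log units; beyond the scatter) from compound 2 to compound 4, 1.6-fold (0.19 log units) apart, within the scatter of two such steps. Within the data shown here, these are only two pairs, so they do not show that the step would hold on other cores, nor do they explain why the number rises.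

The compounds shown leave open how a carboxylic acid, an amine or a longer chain would behave at this place, on a saturated chain carbon bound to a saturated ring carbon.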